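The source may report more compounds than this note shows. Statements on the series, on what has been measured and on what is new or still open speak of the compounds shown alone.

Among the measured compounds shown here, compound 1, `COc1cc2c(Nc3cc(F)ccc3Br)ncnc2c(OC)c1OC`, is the weaker of the two compounds measured so far in a functional assay on SGC-7901 cells (Homo sapiens) for antiproliferative activity, read by MTT assay, with a stated time of 72 h (on this read-out higher numbers stand for weaker inhibition and lower numbers for stronger inhibition), where compound 1 gives 18400 nM. Its nearest neighbour is compound 2, `COc1cc2c(Nc3ccc(Br)c(Cl)c3F)ncnc2c(OC)c1OC`, and in this assay compound 2 gives 15000 nM, a number that lies within the usual scatter of the number for compound 1, so the two are best read as equivalent. The next compound, compound 3, `C#Cc1cccc(Nc2ncnc3c(OC)c(OC)c(OC)cc23)c1`, has not yet been measured in this assay. It differs from compound 1 in one place: 3-ethynylphenyl in place of 2-bromo-5-fluorophenyl on a nitrogen on an aromatic ring. For the measured compounds named here, no step between two measured compounds isolates such a change, so there is nothing in the data that would set its size or direction; the expectation must stay close to what compound 1 shows. Compound 3 is therefore estimated to reach 12000 nM in this assay, within a range of 3000 nM to 45000 nM, which amounts to an expected step of a 1.5-fold lower number from compound 1 to compound 3 (0.19 log units; within the scatter) that is not clearly beyond the scatter.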

Compound 3, half-maximal inhibitory concentration: 5820 nM
For compound 3 the middle estimate is 2.1-fold (0.31 log units) above the measured one; measured number inside the range.
By their numbers in this assay, from the lowest: compound 3; then compounds 2 and 1 (each within the scatter of the next).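

Until now the group on this aromatic nitrogen had only been seen as a halogen-bearing phenyl, and those compounds could not be told apart. With 3-ethynylphenyl in place of 2-bromo-5-fluorophenyl, this assay gives a 3.2-fold lower number from compound 1 to compound 3 (0.50 log units; beyond the scatter) as a modest step, so this position does respond to the group it carries, and a phenyl with no bromine or fluorine but with a triple bond is tolerated. Nothing measured on these compounds accounts for the size or direction of this step.

Since the bromine and fluorine leave as the triple bond enters, these compounds do not separate the loss of the halogens from the gain of the ethynyl. They also leave open whether a plain phenyl, or a phenyl carrying a nitrile or an amine in place of the ethynyl, would behave in the same way.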